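Hydroxy to methoxy: expected effect on compound 4

The source may report more compounds than this note shows. Statements on the series, on what has been measured and on what is new or still open speak of the compounds shown alone.

Compound 3 `CCCCC(O)c1cccc(NC(=O)NC(=O)CCl)c1` gives 5700 nM in a functional assay on MCF7 cells (Homo sapiens) for antiproliferative activity, with a stated time of 48 h (a lower number here means a stronger inhibitor, a higher number a weaker inhibitor), the lowest of the three numbers shown, though compound 2 `CCCCCc1cccc(NC(=O)NC(=O)CCl)c1` with 8300 nM lies within the scatter of it; compound 1 `CCCCC(OC)c1cccc(NC(=O)NCCCCl)c1` with 50000 nM lies beyond it. Compound 4 `CCCCC(OC)c1cccc(NC(=O)NC(=O)CCl)c1` carries methyl in place of hydrogen on an oxygen on a saturated carbon. Among the compounds with values here, the only measured step at that saturated carbon, a 1.5-fold lower number from compound 2 to compound 3 (0.16 log units; within the scatter), was small, and it concerned hydrogen to hydroxy rather than hydroxy to methoxy. Within the data shown here, compound 1 also bears the methoxy but differs from compound 4 in the urea chain, so no step is defined; its value and that of compound 3 show only a wide gap between the two chains. The expected step is therefore a 1.4-fold higher number from compound 3 to compound 4 (0.15 log units; within the scatter), none beyond the scatter. Compound 4 is estimated at 8000 nM, range 3000 nM to 25000 nM.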

Compound 4, half-maximal inhibitory concentration: 6100 nM
Beside the measured number, compound 4's estimate is 1.3-fold (0.12 log units) above it; the measured number falls inside the stated range.
By their numbers in this assay, from the lowest: compounds 3, 4 and 2 (each within the scatter of the next); then compound 1.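

In this assay, methyl in place of hydrogen on the oxygen stays within the scatter (a 1.1-fold higher number from compound 3 to compound 4 (0.03 log units; within the scatter)), as does methoxy in place of hydrogen on the saturated chain carbon (a 1.4-fold lower number from compound 2 to compound 4 (0.13 log units; within the scatter)), so hydrogen, hydroxy and methoxy at this position are not told apart. Within the data shown here, the chain on the amide-type nitrogen gives the first one-place step beyond the scatter (an 8.2-fold lower number from compound 1 to compound 4 (0.91 log units; beyond the scatter)), with (chloromethyl)carbonyl in place of 3-chloropropyl. No evidence bears on these results. Going by these compounds, whether an amine or a longer chain at the saturated carbon would separate from these groups remains open.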